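A few compounds are considered here, and "the series" means these few. Any claim that something is new, unique, unknown or untested is made for them only; others in the source may bear on it.

Measured so far:
compound 1, `COc1ccc(Cc2oc3c(Cl)cc(Cl)c(O)c3c2C)cc1` — 860 nM in a functional assay for inhibition of Polyunsaturated fatty acid 5-lipoxygenase (Homo sapiens), in the absence of a further agent; a higher number here means a weaker inhibitor, a lower number a stronger inhibitor
compound 2, `COc1ccc(Cc2oc3c(Cl)ccc(O)c3c2C)cc1` — 376 nM

Compound 2 gives the lowest of the two numbers in this assay; its nearest neighbour is compound 1, and the step of a 2.3-fold lower number from compound 1 to compound 2 (0.36 log units; beyond the scatter) lies beyond the scatter. Compound 3, `C=CCc1cc(Cl)c2oc(Cc3ccc(OC)cc3)c(C)c2c1O`, is not yet measured there. It differs from compound 2 by allyl in place of hydrogen on an aromatic carbon. For the measured compounds named here, only one measured step exists to lean on, a 2.3-fold lower number from compound 1 to compound 2 (0.36 log units; beyond the scatter), in which removing a group from the shared core lowered the number modestly. Compound 3 moves the other way, gaining a group on that core, so a modest rise in the number, or no change beyond the scatter, is expected for compound 3, as a 1.7-fold higher number from compound 2 to compound 3 (0.24 log units; within the scatter). In this assay compound 3 is therefore estimated at 650 nM, with a range from 250 nM to 1700 nM.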

Compound 3, half-maximal inhibitory concentration: 20 nM
Estimate against measurement, compound 3: 33-fold (1.51 log units) above; measured number below the stated range.
By their numbers in this assay, from the lowest: compound 3; then compound 2; then compound 1.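

In this assay, for the compounds shown here, the aromatic carbon ortho to a hydroxy group proves far more sensitive than the earlier compounds showed, and gaining a group there need not raise the number: allyl in place of hydrogen gives a 19-fold lower number from compound 2 to compound 3 (1.27 log units; beyond the scatter). Allyl in place of chloro at the same carbon gives a 43-fold lower number from compound 1 to compound 3 (1.63 log units; beyond the scatter), whereas hydrogen in place of chloro gave only a 2.3-fold lower number from compound 1 to compound 2 (0.36 log units; beyond the scatter), so the outcome depends on which group sits there and not merely on whether one is present. No measurement at hand accounts for the size of the allyl step.

The compounds shown leave open whether the double bond of allyl matters or the chain alone suffices, which a propyl group at this carbon would test. They also leave open how a methyl group or a longer chain such as butyl would fare there.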